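A naphthalen-2-yl group on the shared core

The compounds below may be only part of what the source reports. "The series", "measured", "known", "first", "only" and "open" are said of these compounds alone.

In a functional assay on HeLa cells (Homo sapiens) for inhibition, read by MTT assay, with a stated time of 48 h (on this read-out lower numbers stand for stronger inhibition and higher numbers for weaker inhibition), compound 1 `Brc1ccc2[nH]cc(C(c3ccccc3)c3c[nH]c4ccc(Br)cc34)c2c1` gives 900 nM and compound 2 `CN(C)c1ccc(C(c2c[nH]c3ccc(Br)cc23)c2c[nH]c3ccc(Br)cc23)cc1` gives 12800 nM, so compound 2 holds the higher of the two numbers. Compound 3 `Brc1ccc2[nH]cc(C(c3ccc4ccccc4c3)c3c[nH]c4ccc(Br)cc34)c2c1` departs from compound 2 in one place: naphthalen-2-yl in place of 4-(dimethylamino)phenyl on a saturated chain carbon bound to two aromatic carbons. Naphthalen-2-yl stands in place of 4-(dimethylamino)phenyl on a saturated chain carbon bound to two aromatic carbons. Within the data shown here, one measured step bears on this, a 14-fold higher number from compound 1 to compound 2 (1.15 log units; beyond the scatter), a large rise that came with dimethylamino in place of hydrogen on an aromatic carbon. Among the measured compounds shown here, compound 3, like compound 1 at 900 nM, carries no dimethylamino group, although no measured compound shows what naphthalen-2-yl itself does. A sizeable fall is therefore expected, and in this assay the estimated step is a 6.4-fold lower number from compound 2 to compound 3 (0.81 log units; beyond the scatter). The estimate for compound 3 is 2000 nM, with an expected range from 600 nM to 7000 nM.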

Compound 3, half-maximal inhibitory concentration: 4300 nM
For compound 3 the middle estimate is 2.2-fold (0.33 log units) below the measured one; the range from low to high includes it.
By their numbers in this assay, from the lowest: compound 1; then compound 3; then compound 2.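

Losing the 4-(dimethylamino)phenyl group recovers only part of the ground in this assay: naphthalen-2-yl brings a 3.0-fold lower number from compound 2 to compound 3 (0.47 log units; beyond the scatter), yet it also brings a 4.8-fold higher number from compound 1 to compound 3 (0.68 log units; beyond the scatter). Among these three compounds, then, phenyl gives the lowest number on the saturated chain carbon bound to two aromatic carbons, and the rise over phenyl is not confined to the compound carrying dimethylamino. No measured evidence accompanies these numbers to account for this order.

As far as these compounds go, it remains open whether the rise seen with compound 2 and compound 3 would recur with other groups at this place, such as pyridin-3-yl, 4-methoxyphenyl or cyclohexyl. Also open, from the compounds shown here alone, is whether naphthalen-1-yl would give a number closer to that of compound 1 or to that of compound 3.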